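Swapping trifluoromethyl for hydroxy on the aniline end

The source may report more compounds than this note shows. Statements on the series, on what has been measured and on what is new or still open speak of the compounds shown alone.

Compound 1 `COc1ccc(-c2nn(-c3ccccc3)cc2C(=O)/C=C\Nc2ccc(C(F)(F)F)cc2)cc1`: in a functional assay on A549 cells (Homo sapiens) for antiproliferative activity, read by MTT assay, with a stated time of 48 h (a lower number here means a stronger inhibitor, a higher number a weaker inhibitor), compound 1 gives > 50000 nM, which is a limit of the assay and not a number.
Compound 2 `COc1ccc(-c2nn(-c3ccccc3)cc2C(=O)/C=C\Nc2ccc(O)cc2)cc1`: in this assay compound 2 gives 2770 nM.
Compound 3 `COc1cc(-c2nn(-c3ccccc3)cc2C(=O)/C=C\Nc2ccc(C(F)(F)F)cc2)cc(OC)c1OC`: in this assay compound 3 gives > 50000 nM, again a limit and not a number.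

Compound 1 and compound 2 share a core and differ in one place, (hydroxy in place of trifluoromethyl on an aromatic carbon). That change gave an at least 18-fold lower number from compound 1 to compound 2 (1.25 log units; beyond the scatter). How far it really reaches is hidden by the limit of > 50000 nM in this assay, at which 2 of the 3 values shown sit, so only its lower bound is known.

Compound 3 differs from compound 1 in the core, (3,4,5-trimethoxyphenyl in place of 4-methoxyphenyl on an aromatic carbon). The step that the two limits leave unreadable from compound 1 to compound 3 cannot be sized, since both values are limits.

Compound 4 `COc1cc(-c2nn(-c3ccccc3)cc2C(=O)/C=C\Nc2ccc(O)cc2)cc(OC)c1OC` is not yet measured. It is made from compound 3 by hydroxy in place of trifluoromethyl on an aromatic carbon, the same change as from compound 1 to compound 2, at a place described in the same words. If the change behaves as it did on the core of compound 1, compound 4 is expected to fall well below the limit at which compound 3 sits, with a step of about an at least 10-fold lower number from compound 3 to compound 4 (1.00 log units; beyond the scatter). Going by these compounds, that expectation rests on an at least 18-fold lower number from compound 1 to compound 2 (1.25 log units; beyond the scatter) alone; what the larger core does is unknown, because a step that the two limits leave unreadable from compound 1 to compound 3 is unreadable. The expected value for compound 4 in this assay is 5000 nM, with a plausible range from 1000 nM to 50000 nM, and a fair chance that only a limit is reported.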

Compound 4, half-maximal inhibitory concentration: 3160 nM
Compound 4: the middle estimate sits 1.6-fold (0.20 log units) above what was measured; measured number inside the range.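

In this assay, hydroxy in place of trifluoromethyl on the core of compound 3 gave an at least 15-fold lower number from compound 3 to compound 4 (1.19 log units; beyond the scatter), so the large drop seen on the core of compound 1 appeared again on a second core. Set side by side, the two steps point the same way, but each is only a lower bound, and this does not show that the change is worth the same on both cores: the same change on two cores in this assay, an at least 18-fold lower number (1.25 log units; beyond the scatter) from compound 1 to compound 2 and an at least 15-fold lower number (1.19 log units; beyond the scatter) from compound 3 to compound 4; the limit leaves it open whether they differ. Two cores make no rule for others, the step between the two trifluoromethyl compounds cannot be read, and the full size of each hydroxy step stays hidden: the limit of > 50000 nM in this assay, at which 2 of the 4 values shown sit.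

The compounds shown leave open whether hydroxy is special at this place or whether other groups there, such as an amine, a carboxylic acid or a single fluorine, would also bring the number down from the limit. They also leave open how far the change carries onto cores further from these two, for example one with a chlorine in place of the methoxy groups on the phenyl ring.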